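Spirooxindole series: paw edema inhibition, thiophene for fluorophenyl

The compounds below may be only part of what the source reports. "The series", "measured", "known", "first", "only" and "open" are said of these compounds alone.

Measured so far:
compound 1, `CN1C[C@@H](c2ccccc2)[C@@]2(Cc3ccccc3C2=O)[C@@]12C(=O)Nc1ccccc12`, 39.3%
compound 2, `CN1C(=O)[C@@]2(c3ccccc31)N(C)C[C@@H](c1ccc(F)cc1)[C@@]21Cc2ccccc2C1=O`, 25.5%

In a functional assay on the whole organism (strain Wister albino) for inhibition, with Rattus norvegicus as the target, read by paw edema, with stated times of 1 h and 4 h, at a dose of 50 mg/kg by the intraperitoneal route (a higher number here means more inhibition at the dose given (going by the name of the read-out), a lower number less inhibition), compound 2 gives 25.5%, the lowest of the two numbers recorded. Compound 1 gives 39.3% in this assay, a figure that stands above compound 2 by more than the usual scatter. Going by the values given here, compound 1 and compound 2 differ in more than one place, so no single step between them is recorded; their two values show only that compound 1 inhibits more at the dose used.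

Compound 3, `CN1C(=O)[C@@]2(c3ccccc31)N(C)C[C@@H](c1cccs1)[C@@]21Cc2ccccc2C1=O`, is not yet measured in this assay. It differs from compound 2 as follows: thiophen-2-yl in place of 4-fluorophenyl on a saturated ring carbon. The core and both methyl-bearing nitrogens are kept; only the aryl group on the saturated ring carbon changes.

Among the compounds with values here, with no measured step for this exchange, the expected step is a number 1.5 percentage points higher from compound 2 to compound 3 (within the scatter), that is, no change beyond the scatter, perhaps a small drift either way. Compound 3 is therefore estimated at 27% in this assay, within a range of 15% to 40%.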

Compound 3, a percentage reported as inhibition, in the whole organism at one dose (the size of the read-out at that dose, not a potency): 12.9%
Compound 3: middle estimate off by 14.1 percentage points, on the high side; measured number outside the range, below it.
By their numbers in this assay, from the lowest: compound 3; then compound 2; then compound 1.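

Going by these compounds alone, the exchange gives the first step that can be read at a single place: in this assay, the move from 4-fluorophenyl to thiophen-2-yl on the saturated ring carbon gives a number 12.6 percentage points lower from compound 2 to compound 3 (beyond the scatter). With the core and both methyl-bearing nitrogens kept, the read-out at the dose given therefore depends on which aromatic ring sits at this position, and a five-membered aromatic ring with 1 hetero atom is not interchangeable here with the six-membered aromatic ring of carbon only. No measurement at hand bears on the cause of this step.

Within the data shown here, it remains open whether the step reflects the thiophen-2-yl ring itself or the loss of the 4-fluorophenyl group's fluorine, as the only compound here with an unsubstituted phenyl at this carbon is compound 1, which differs from compound 2 in more than one place. Also open, from the compounds shown here alone, is how the same saturated ring carbon would read with a pyridin-2-yl, a furan-2-yl or a 4-methoxyphenyl group, and whether any aryl group there would carry the read-out past that of compound 2.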